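A cyclopropyl variant of compound 2 in this series

The source may hold more compounds than are shown below. What is called first, only, known or untested is meant among the compounds shown, and "the series" means these compounds.

Compound 1 `Cc1cc(C)c(-c2csc(NC(=O)/C=C/c3ccc(C(C)(C)C)cc3)n2)c(C)c1` — in an ADME assay on L02 cells (Homo sapiens) for inhibition, read by MTT assay, with a stated time of 96 h (on this read-out higher numbers stand for weaker inhibition and lower numbers for stronger inhibition), compound 1 gives > 90000 nM, which is a limit of the assay and not a number.
Compound 2 `Cc1cc(C)c(-c2csc(NC(=O)/C=C/c3ccc(C(F)(F)F)cc3)n2)c(C)c1` — in this assay compound 2 gives > 90000 nM, again a limit of the assay and not a number.

Going by the values given here, compound 2 therefore stands at the limit, and the one other value shown is a limit as well. The step that the two limits leave unreadable from compound 1 to compound 2 cannot be sized because the limit of > 90000 nM in this assay, at which 2 of the 2 values shown sit, caps both values. The next change is cyclopropyl in place of trifluoromethyl on an aromatic carbon, giving compound 3 `Cc1cc(C)c(-c2csc(NC(=O)/C=C/c3ccc(C4CC4)cc3)n2)c(C)c1`. Among the compounds with values here, the only measured step bears on it in that it also exchanges the group on this aromatic carbon, but it yields no readable size and no direction. No step beyond the scatter is expected in this assay, and the result is expected most likely to be a limit again. For compound 3 the expected value is 150000 nM, with a range from 60000 nM to 400000 nM. The estimated step that the limit leaves unreadable from compound 2 to compound 3 is expected to lie within the scatter.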

Compound 3, half-maximal inhibitory concentration: > 90000 nM
Compound 3: no number, only a limit (the forecaster's own chance of this, stated with the estimate: 85%); the middle value lies beyond the limit too.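

No step among compound 1, compound 2 and compound 3 can be read in this assay, because all three stand at a limit of the assay and not at a number: the limit of > 90000 nM in this assay, at which 3 of the 3 values shown sit.

The compounds shown leave open whether any group on this aromatic carbon gives a measurable value in this assay.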